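A few compounds are considered here, and "the series" means these few. Any claim that something is new, unique, unknown or untested is made for them only; others in the source may bear on it.

Measured compounds:
compound 1, `N[C@@H](CC(=O)OC[C@H]1O[C@@H](n2cc(F)c(=O)[nH]c2=O)C[C@@H]1O)C(=O)O` — 0.273 h
compound 2, `N[C@@H](CCC(=O)O[C@H]1C[C@H](n2cc(F)c(=O)[nH]c2=O)O[C@@H]1CO)C(=O)O` — 0.17 h

In an ADME assay on tissue (MIA PaCa-2 cells, Homo sapiens) for pharmacokinetics (on this read-out lower numbers stand for a shorter-lived compound and higher numbers for a longer-lived compound), compound 1 gives 0.273 h, the higher of the two numbers recorded so far, while compound 2 gives 0.17 h. The gap between compound 1 and compound 2 lies within the usual scatter of repeated measurements, so the two cannot be ordered from these numbers alone.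

Compound 3, `CC(C)[C@H](N)C(=O)OC[C@H]1O[C@@H](n2cc(F)c(=O)[nH]c2=O)C[C@@H]1O`, has not yet been measured in this assay. It differs from compound 1 in one place: 1-amino-2-methylpropyl in place of 2-amino-2-carboxyethyl on a carbonyl carbon. Among the compounds with values here, no step between two measured compounds resembles this change, so there is nothing in the numbers to anchor its size or direction.

The half-life of compound 3 in this assay is therefore expected to stay close to that of compound 1, with a step from compound 1 to compound 3 of a 1.1-fold higher number from compound 1 to compound 3 (0.04 log units; within the scatter) that does not go beyond the scatter. The estimate for compound 3 is 0.3 h, within a range of 0.12 h to 0.8 h.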

Compound 3, half-life: 0.188 h
The estimate for compound 3 lay 1.6-fold (0.20 log units) above the measured number; measured number inside the range.
By their numbers in this assay, from the lowest: compounds 2, 3 and 1 (each within the scatter of the next).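

In this assay, the first change read at this carbonyl carbon, 1-amino-2-methylpropyl in place of 2-amino-2-carboxyethyl, gives a 1.5-fold lower number from compound 1 to compound 3 (0.16 log units; within the scatter), so the step cannot be told from repeat-measurement noise. On the core of compound 1, a group without the carboxy part therefore leaves the half-life indistinguishable from that with it, and the carboxy part is not shown to matter here. Nothing measured in this series speaks to the reason for this.

On these data alone, both groups at this place carry an amine, so the effect of a plain alkyl chain without one remains open. Also open, as far as these compounds go, is whether a longer chain or a phenyl ring on this carbonyl carbon would move the half-life beyond the scatter.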